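This account rests on a few compounds, and the source may have more. Where it says the series, first, only, none or still open, it means among the compounds named here.

Measured compounds in a functional assay on MIA PaCa-2 cells (Homo sapiens) for antiproliferative activity, read by sulforhodamine B assay, with a stated time of 48 h; a higher number here means a weaker inhibitor, a lower number a stronger inhibitor:
compound 1 `COc1ccc(C(=O)/C=C\Nc2ccc(-c3nc4cc(OC)c(OC)c(OC)c4s3)cc2C)cc1F` gives 1800 nM
compound 2 `COc1ccc(C(=O)/C=C\Nc2ccc(-c3nc4cc(OC)c(OC)c(OC)c4s3)cc2)cc1F` gives 19400 nM
compound 3 `COc1ccc2nc(-c3ccc(N/C=C\C(=O)c4cc(OC)c(OC)c([N+](=O)[O-])c4)cc3)sc2c1` gives 25600 nM

Within the data shown here, compound 2 and compound 1 share a core and differ in one place: methyl in place of hydrogen on an aromatic carbon That single change gives an 11-fold lower number from compound 2 to compound 1 (1.03 log units; beyond the scatter) in this assay, the one large step among the three measured compounds.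

Compound 3 carries a different core from compound 2; the difference between the two cores is not broken down here. In this assay compound 3 and compound 2 sit close together, and both stand well apart from compound 1.

Compound 4 `COc1ccc2nc(-c3ccc(N/C=C\C(=O)c4cc(OC)c(OC)c([N+](=O)[O-])c4)c(C)c3)sc2c1` is not yet measured. It stands to compound 3 as compound 1 stands to compound 2: methyl in place of hydrogen on an aromatic carbon The surroundings of the place are not identical, since in compound 4 the new group is meta to a 6-methoxy-1,3-benzothiazol-2-yl group, whereas in compound 1 it is meta to a large group; so this is the same kind of change, not the same change. Among the measured compounds shown here, with only one earlier example of it, and that on another core, the expectation rests on the size of the step from compound 2 to compound 1 and allows for some attenuation.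

For compound 4 in this assay the expected step is a 7.3-fold lower number from compound 3 to compound 4 (0.86 log units; beyond the scatter), because the earlier instance gave an 11-fold lower number from compound 2 to compound 1 (1.03 log units; beyond the scatter). Compound 4 is estimated at 3500 nM, with a likely range from 1200 nM to 12000 nM.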

Compound 4, half-maximal inhibitory concentration: 12000 nM
Compound 4: the middle estimate sits 3.4-fold (0.54 log units) below what was measured; the range from low to high includes it.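

In this assay, methyl in place of hydrogen on an aromatic carbon lowers the number on the second core as well, giving a 2.1-fold lower number from compound 3 to compound 4 (0.33 log units; beyond the scatter), so the direction of the step carries over from one core to the other, while its size does not: the same change on two cores in this assay, an 11-fold lower number (1.03 log units; beyond the scatter) from compound 2 to compound 1 and a 2.1-fold lower number (0.33 log units; beyond the scatter) from compound 3 to compound 4, 5.1-fold (0.70 log units) apart, beyond the scatter of two such steps

The change can therefore be expected to help in this series only in direction, and a step measured on one core is a poor guide to the size of the step on another. With just two instances, and with the two cores differing in more than one place, these compounds do not show which part of the core sets the size of the step, and they give no cause for the gap between the two steps.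

Going by these compounds, whether an ethyl group, a chlorine atom or an amine on the same aromatic carbon would also lower the number remains open, as does the effect of a longer chain there. Also open, on these data alone, is whether a third core would give a step nearer the larger or the smaller of these two, and whether the same pattern would appear in any cell line other than the one in this assay.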